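The source may report more compounds than this note shows. Statements on the series, on what has been measured and on what is new or still open speak of the compounds shown alone.

Compound 1 `COc1ccccc1C#Cc1nc2c(s1)C(=O)NCC2`: in an assay on HEK293 cells for positive allosteric modulation of metabotropic glutamate receptor 5 (Homo sapiens), read by FLIPR, with a stated time of 1 h (on this read-out lower numbers stand for an effect already at smaller amounts and higher numbers for an effect only at larger amounts of compound), compound 1 gives > 10000 nM, a limit of the assay and not a number.
Compound 2 `Fc1cccc(C#Cc2nc3c(s2)CN(C2CCOC2)CC3)c1`: in this assay compound 2 gives > 10000 nM, again a limit.
Compound 3 `O=C(C1CC12CCC2)N1CCc2nc(C#Cc3ccccc3)sc2C1`: in this assay compound 3 gives 3.9 nM.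

Going by the values given here, compound 3 thus carries the only measured number in the set; the other two values sit at the limit of > 10000 nM in this assay, at which 2 of the 3 values shown sit. Among the compounds with values here, no step between measured compounds that differ in a single place is available, so the shared core of compound 3 has no paired comparison to rest on.

Compound 4 `O=C(c1cccc(Cl)c1)N1CCc2nc(C#Cc3ccccc3)sc2C1` differs from compound 3 by a group of 7 heavy atoms (6 carbon, 1 chlorine; one six-membered aromatic ring of carbon only) in place of a group of 6 heavy atoms (6 carbon; one three-membered non-aromatic ring of carbon only, one four-membered non-aromatic ring of carbon only), on a carbonyl carbon. With the carbonyl and the amide-type nitrogen in the ring kept, the step from compound 3 to compound 4 is expected to stay small, a 2.1-fold higher number from compound 3 to compound 4 (0.31 log units; beyond the scatter), within or close to the usual scatter. Compound 4 is therefore estimated at 8 nM, with a range from 2 nM to 40 nM.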

Compound 4, half-maximal effective concentration: 8.7 nM
Beside the measured number, compound 4's estimate is 1.1-fold (0.04 log units) below it; low and high end bracket the measured number.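

Going by these compounds alone, this is the first paired comparison: in this assay, the change on the carbonyl carbon gives a 2.2-fold higher number from compound 3 to compound 4 (0.35 log units; beyond the scatter). The place therefore takes a 3-chlorophenyl, with its six-membered aromatic ring, as well as the group with three- and four-membered non-aromatic rings, at a modest cost. Neither group carries a hydrogen-bond donor or acceptor, so this single pair covers only groups of that kind.

As far as these compounds go, what the chlorine itself contributes remains open. So does how an amine or a carboxylic acid would read on this carbonyl carbon.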